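Ethyl on the amide nitrogen: compound 1 to compound 4

The compounds below may be only part of what the source reports. "The series", "measured", "known", "first", "only" and "open" are said of these compounds alone.

Measured so far:
compound 1 `CC[C@@H]1C(=O)N(C)c2cnc(-n3ccc4cc(C(N)=O)ccc43)nc2N1C1CCCC1` — 4350 nM
compound 2 `CCCCNS(=O)(=O)c1ccc(Nc2ncc3c(n2)N(C2CCCC2)[C@H](CC)C(=O)N3C)cc1` — 477 nM
compound 3 `CCC1C(=O)N(C)c2cnc(-n3ccc4cc(C(=O)NCC(C)C)ccc43)nc2N1c1ccn(C)n1` — 19200 nM

Among the three measured compounds, compound 1 stands second highest in a functional assay on A549 cells (Homo sapiens) for antiproliferative activity, read by CCK-8 assay, with a stated time of 72 h; a lower number here means a stronger inhibitor of growth, a higher number a weaker inhibitor of growth: compound 3 gives a higher number, beyond the scatter, and compound 2 gives a lower number, also beyond the scatter. Compound 4 `CCNC(=O)c1ccc2c(ccn2-c2ncc3c(n2)N(C2CCCC2)[C@H](CC)C(=O)N3C)c1` has not yet been measured. It differs from compound 1 in one place: ethyl in place of hydrogen on an amide-type nitrogen. For the measured compounds named here, no measured pair in the set shows this difference on its own, so there is no anchor for its size. The expectation is a small step from compound 1, within or close to the scatter, of a 1.1-fold higher number from compound 1 to compound 4 (0.06 log units; within the scatter). Compound 4 is therefore estimated at 5000 nM, with a range from 1500 nM to 15000 nM.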

Compound 4, concentration for 50% growth inhibition: 1120 nM
Beside the measured number, compound 4's estimate is 4.5-fold (0.65 log units) above it; measured number below the stated range.
By their numbers in this assay, from the lowest: compound 2; then compound 4; then compound 1; then compound 3.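

In this assay the amide hydrogen can be replaced: ethyl in its place gives a 3.9-fold lower number from compound 1 to compound 4 (0.59 log units; beyond the scatter) and the change lies beyond the scatter. For the compounds shown here, this is the first single-place step, and it shows that substitution on this amide-type nitrogen alone can shift antiproliferative activity with the rest of compound 1 unchanged. Nothing measured here gives a reason for the shift.
Going by these compounds, whether a longer chain continues the trend remains open. So does the outcome with a chain ending in an amine or a carboxylic acid on this nitrogen.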